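Methylsulfanyl for ethyl on the chalcone aryl ring

A few compounds are considered here, and "the series" means these few. Any claim that something is new, unique, unknown or untested is made for them only; others in the source may bear on it.

The series shares a benzoxaborole-bearing enone core; compound 1 `O=C(/C=C/c1ccc2c(c1)B(O)OC2)c1ccccc1` carries an unsubstituted phenyl ketone and compound 2 `CCc1ccc(C(=O)/C=C/c2ccc3c(c2)B(O)OC3)cc1` carries an ethyl group on that ring. In a functional assay on SK-OV-3 cells (Homo sapiens) for cytotoxicity, read by MTT assay, with a stated time of 48 h (a lower number here means a stronger inhibitor, a higher number a weaker inhibitor), compound 1 gives 3400 nM, and in this assay compound 2 gives 4400 nM. The step of a 1.3-fold higher number from compound 1 to compound 2 (0.11 log units; within the scatter) lies within the scatter, so the two values cannot be told apart, and compound 2 stands on the same footing as compound 1 rather than apart from it.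

Compound 3 `CSc1ccc(C(=O)/C=C/c2ccc3c(c2)B(O)OC3)cc1` differs from compound 2 by methylsulfanyl in place of ethyl on an aromatic carbon. Within the data shown here, no measured step touches a methylsulfanyl group; the only step at that aromatic carbon, a 1.3-fold higher number from compound 1 to compound 2 (0.11 log units; within the scatter), is within the scatter, and it shows that adding a small group at this place left this assay essentially unchanged. On that basis a step of a 1.1-fold lower number from compound 2 to compound 3 (0.04 log units; within the scatter) is expected for compound 3, that is, no movement beyond the scatter. Compound 3 is therefore estimated at 4000 nM in this assay, with a range of 1800 nM to 9000 nM.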

Compound 3, half-maximal inhibitory concentration: 4100 nM
The estimate for compound 3 lay 1.0-fold (0.01 log units) below the measured number; measured number inside the range.
By their numbers in this assay, from the lowest: compounds 1, 3 and 2 (each within the scatter of the next).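

In this assay, methylsulfanyl in place of ethyl on this aromatic carbon, para to a large group, gives a 1.1-fold lower number from compound 2 to compound 3 (0.03 log units; within the scatter) and so leaves the number unmoved, although methylsulfanyl counts 1 hydrogen-bond acceptor and 1 sulfur where ethyl counts 0 hydrogen-bond acceptors and no sulfur. Among these compounds, measured against the hydrogen of compound 1, the same group gives a 1.2-fold higher number from compound 1 to compound 3 (0.08 log units; within the scatter) and thus adds a second substituent to the earlier ethyl step, a 1.3-fold higher number from compound 1 to compound 2 (0.11 log units; within the scatter), so that hydrogen, ethyl and methylsulfanyl at this place, across compounds 1, 2 and 3, cannot be told apart in this read-out, where the earlier pair offered only one substituent for comparison. No evidence is at hand that would explain this flat reading.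

Whether it holds for an amine, a carboxylic acid or a longer chain such as hexyl at this aromatic carbon stays open, as the three compounds shown span only hydrogen, ethyl and methylsulfanyl. Also open is whether any group here can shift the number beyond the scatter in either direction, since none of the steps shown does so.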